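This account rests on a few compounds, and the source may have more. Where it says the series, first, only, none or still open, it means among the compounds named here.

Measured so far:
- compound 1 `NC(=O)c1cc(-c2ccccc2)cc2c(C3CCN(S(=O)(=O)CCCNC4CCCC4)CC3)c[nH]c12` gives 140 nm/s
- compound 2 `CCN(CC)CCCS(=O)(=O)N1CCC(c2c[nH]c3c(C(N)=O)cc(-c4ccccc4)cc23)CC1` gives 200 nm/s

In an ADME assay for permeability, using PAMPA (a higher number here means that the compound crosses the layer faster, a lower number that the compound crosses the layer more slowly), compound 2 sits within the scatter of compound 1, so the two stand level. Compound 3 `CCS(=O)(=O)N1CCC(c2c[nH]c3c(C(N)=O)cc(-c4ccccc4)cc23)CC1` follows from compound 2 by hydrogen in place of (diethylamino)methyl on a saturated chain carbon, two bonds along the chain from a sulfonyl sulfur. Going by the values given here, the only measured step (a 1.4-fold higher number from compound 1 to compound 2 (0.15 log units; within the scatter)) swaps cyclopentylamino for diethylamino and keeps the chain, so it offers little guidance. Among the compounds with values here, no measured compound lacks the amine, which leaves the direction a judgement with wide uncertainty. A modest rise is expected (a 1.8-fold higher number from compound 2 to compound 3 (0.24 log units; within the scatter)). Compound 3 is estimated at 350 nm/s (range 130 nm/s to 900 nm/s).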

Compound 3, apparent permeability: 250 nm/s
Compound 3: the middle estimate sits 1.4-fold (0.15 log units) above what was measured, and the stated range covers the measured number.
By their numbers in this assay, from the lowest: compounds 1, 2 and 3 (each within the scatter of the next).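

In this assay the amine on the chain can go without the number leaving the scatter: hydrogen in place of (diethylamino)methyl (a 1.3-fold higher number from compound 2 to compound 3 (0.10 log units; within the scatter)) and hydrogen in place of (cyclopentylamino)methyl (a 1.8-fold higher number from compound 1 to compound 3 (0.25 log units; within the scatter)) both leave the compounds level. On this saturated chain carbon, two bonds along the chain from a sulfonyl sulfur, compounds 1, 2 and 3 therefore stand level with or without the amine. Nothing available accounts for this result.

Still open, from the compounds shown here alone, is how a carboxylic acid or a hydroxyl group at this place would read, and whether a longer chain without an amine would stand level with compound 3.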